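From Bromo to Methylsulfonyl: Expecting Compound 4

The source may hold more compounds than are shown below. What is called first, only, known or untested is meant among the compounds shown, and "the series" means these compounds.

Compound 2 `O=C(O)c1cccc(C2=C(c3cc(Br)ccc3OCc3ccc(F)cc3F)CCC2)c1` was tested in an assay on isolated protein for inhibition of prostaglandin E2 receptor EP3 subtype (Homo sapiens); on this read-out lower numbers stand for stronger inhibition and higher numbers for weaker inhibition. In this assay compound 2 gives < 3170 nM, which is a limit of the assay rather than a number. Its close relatives show the same picture: compound 1 `O=C(O)c1cccc(C2=C(c3cc(Br)ccc3OCc3ccc(F)cc3)CCC2)c1` gives < 3170 nM, again a limit. Compound 3 `O=C(O)c1cccc(C2=C(c3cc(Br)ccc3OCc3ccccc3)CCC2)c1` gives < 3170 nM, likewise a limit. Hence the steps a step that the two limits leave unreadable from compound 1 to compound 2, a step that the two limits leave unreadable from compound 1 to compound 3 and a step that the two limits leave unreadable from compound 2 to compound 3 cannot be sized, because of the limit of < 3170 nM in this assay, at which 3 of the 3 values shown sit. Compound 4 `CS(=O)(=O)c1ccc(OCc2ccc(F)cc2F)c(C2=C(c3cccc(C(=O)O)c3)CCC2)c1` differs from compound 2 by methylsulfonyl in place of bromo on an aromatic carbon. For the measured compounds named here, none of the measured steps touches this position, so they give no size for the change. Compound 4 is therefore expected near 400 nM, between 40 nM and 3000 nM. The step from compound 2 to compound 4 is estimated at a step that the limit leaves unreadable from compound 2 to compound 4.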

Compound 4, half-maximal inhibitory concentration: < 3170 nM
Compound 4: a limit, no number; the forecaster's own chance of this, stated with the estimate: 60%; the middle value lies beyond the limit too.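

No step can be sized from compound 2 to compound 4, because neither result is a number: the limit of < 3170 nM in this assay, at which 4 of the 4 values shown sit.

As far as these compounds go, it remains open how strongly compound 1, compound 2, compound 3 and compound 4 actually inhibit in this assay, and whether any of these changes matters.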